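The compounds below may be only part of what the source reports. "The series", "measured", "known", "first", "only" and "open" are said of these compounds alone.

Compound 1, `COc1ccc(C(=O)/C=C/c2cc(-c3cc(OC)c(OC)c(OC)c3)n[nH]2)cc1OC`, was tested in a functional assay on LOX IMVI cells (Homo sapiens) for cytotoxicity, read by sulforhodamine B assay, with a stated time of 48 h, tested at 0.1 uM (a higher number here means a weaker effect of the compound at the concentration tested, a lower number a stronger effect), where compound 1 gives 92%. For the measured compounds named here, only one other number is available: compound 2, `COc1cc(-c2cc(/C=C/C(=O)c3ccc(F)c(F)c3)[nH]n2)cc(OC)c1OC`, gives 94% in this assay. The two numbers sit within the scatter of each other, since the step from compound 1 to compound 2 amounts to a number 2 percentage points higher from compound 1 to compound 2 (within the scatter), so neither compound can be set apart from the other on this reading; compound 1 simply has the smaller of the two figures.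

Compound 3, `COc1cc(C(=O)/C=C/c2cc(-c3cc(OC)c(OC)c(OC)c3)n[nH]2)cc(OC)c1OC`, differs from compound 1 by methoxy in place of hydrogen on an aromatic carbon. Going by the values given here, the single measured step, a number 2 percentage points higher from compound 1 to compound 2 (within the scatter), exchanged the entire aryl group on the carbonyl carbon and left the number essentially unchanged. The change to compound 3 touches that same ring, adding a methoxy where compound 1 bears hydrogen. Among the compounds with values here, no measured step tests this exact addition, so the only guide is the indifference of this assay to the earlier exchange. On that basis, no step beyond the scatter is expected: no change at the digits printed from compound 1 to compound 3 (within the scatter). Compound 3 is therefore estimated at 92%, with a range from 80% to 102%.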

Compound 3, a percentage reported as activity, at one concentration (the size of the read-out at that concentration, not a potency): 101%
The estimate for compound 3 lay 9 percentage points below the measured number; the measured number falls inside the stated range.
By their numbers in this assay, from the lowest: compounds 1, 2 and 3 (each within the scatter of the next).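

In this assay, methoxy in place of hydrogen on an aromatic carbon, ortho to a methoxy group and meta to a large group, gives a number 9 percentage points higher from compound 1 to compound 3 (within the scatter). The earlier step exchanged a whole aryl group, whereas this one tests a single added methoxy at one position of the ring, and on this reading that addition does not set compound 3 apart from compound 1. No measurement available here bears on why the assay responds in this way.

As far as these compounds go, it remains open whether a different group at this position, such as an amine, a carboxylic acid or a longer chain like butoxy, would produce a step beyond the scatter. From the compounds shown here alone, since each compound is read at only one concentration, it also remains open whether compound 1 and compound 3 would separate at a concentration where the read-out is further from these values.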